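From Hydroxy to Phenoxy on a Shared Core

The compounds below may be only part of what the source reports. "The series", "measured", "known", "first", "only" and "open" are said of these compounds alone.

Compound 1 (`CC1=C(C(=O)Nc2ccc(Cl)c(Cl)c2)C(c2cccc(O)c2)NC(=S)N1`) and compound 2 (`CC1=C(C(=O)Nc2ccc(F)c(Cl)c2)C(c2ccccc2Cl)NC(=S)N1`) share a core and were both examined in a functional assay on IGROV-1 cells (Homo sapiens) for cytotoxicity, read by sulforhodamine B assay, with a stated time of 48 h; a higher number here means a weaker inhibitor of growth, a lower number a stronger inhibitor of growth. Compound 1 gives 19100 nM, and compound 2 gives 17800 nM; the two values lie within the scatter of each other, so compound 1 holds the higher of the two numbers without being set apart from compound 2. Compound 3 (`CC1=C(C(=O)Nc2ccc(Cl)c(Cl)c2)C(c2cccc(Oc3ccccc3)c2)NC(=S)N1`) has not yet been measured. It differs from compound 1 in a single place: phenyl in place of hydrogen on an oxygen on an aromatic ring, which cut one bond further out reads hydroxy to phenoxy. Going by the values given here, no measured pair shows this change, so its effect here is unknown; the two values in hand are close, and a step of modest size in either direction, or none beyond the scatter, is the most that can be expected. Compound 3 is accordingly estimated at 15000 nM in this assay, within a range from 5000 nM to 50000 nM, which corresponds to an expected step of a 1.3-fold lower number from compound 1 to compound 3 (0.10 log units; within the scatter).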

Compound 3, concentration for 50% growth inhibition: 7760 nM
Compound 3: the middle estimate sits 1.9-fold (0.29 log units) above what was measured; the range from low to high includes it.
By their numbers in this assay, from the lowest: compound 3; then compounds 2 and 1 (each within the scatter of the next).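

Exchanging hydroxy for phenoxy gives a 2.5-fold lower number from compound 1 to compound 3 (0.39 log units; beyond the scatter) in this assay, a modest step, but one that lies beyond the scatter. Going by these compounds alone, this is the first step on the shared core that can be read at all, and it shows that a phenyl on this oxygen on an aromatic ring is compatible with stronger growth inhibition, not weaker. No measurement shown here explains the step, so its cause remains unknown.

As far as these compounds go, whether the change in number comes from the added phenyl ring or simply from the loss of the hydrogen on the oxygen stays open, and a methoxy or benzyloxy group at this place would be needed to separate the two. From the compounds shown here alone, it is also open whether an amine or a carboxylic acid at this place would move the number in the same direction.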